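Furan-2-yl in place of cyclopentyl: expected cytotoxicity of compound 4

The source may report more compounds than this note shows. Statements on the series, on what has been measured and on what is new or still open speak of the compounds shown alone.

The shared core is that of compound 1 `O=C(Nc1ccc(N2CCCC2)cc1Cl)c1cc(Cl)ccc1O`, for which compound 1 has "not determined" (no result reported) in an ADME assay on A549 cells (Homo sapiens) for cytotoxicity, read by LDH release, with a stated time of 15 h; a higher number here means that more compound is tolerated, a lower number that less compound is tolerated. Compound 2 `O=C(Nc1ccc(NCC2CCCC2)cc1Cl)c1cc(Cl)ccc1O` gives 141000 nM in this assay, the highest of the two numbers in hand. Compound 3 `CCCC(C)(C)Nc1ccc(NC(=O)c2cc(Cl)ccc2O)c(Cl)c1` gives 23700 nM in this assay and is the nearest measured entry. For the measured compounds named here, the one measured step is a 5.9-fold lower number from compound 2 to compound 3 (0.77 log units; beyond the scatter), a 1,1-dimethylbutyl in place of cyclopentylmethyl on a nitrogen on an aromatic ring.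

Compound 4 `O=C(Nc1ccc(NCc2ccco2)cc1Cl)c1cc(Cl)ccc1O` differs from compound 2 as follows: furan-2-yl in place of cyclopentyl on a saturated chain carbon bound to a nitrogen on an aromatic ring. Going by the values given here, no measured pair shows this exchange; the one measured step changes the whole group on the nitrogen rather than the ring at the end of the methylene, so it bears on the present step only as a sign of how far a change at this part of compound 2 can move the number. With nothing more to go on, the expectation for compound 4 is a number close to that of compound 2, perhaps a little lower. For compound 4 the estimated value is 100000 nM, with a range from 35000 nM to 250000 nM. For compound 4 this means an expected step of a 1.4-fold lower number from compound 2 to compound 4 (0.15 log units; within the scatter), not clearly beyond the scatter.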

Compound 4, half-maximal cytotoxic concentration: 76300 nM
Compound 4: the middle estimate sits 1.3-fold (0.12 log units) above what was measured; the measured number falls inside the stated range.
By their numbers in this assay, from the lowest: compound 3; then compounds 4 and 2 (each within the scatter of the next).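

In this assay, furan-2-yl in place of cyclopentyl on a saturated chain carbon bound to a nitrogen on an aromatic ring gives a 1.8-fold lower number from compound 2 to compound 4 (0.27 log units; within the scatter), so this read-out does not separate the five-membered aromatic ring carrying one oxygen from the five-membered ring of carbon only. (Furan-2-yl)methyl in place of 1,1-dimethylbutyl gives a 3.2-fold higher number from compound 3 to compound 4 (0.51 log units; beyond the scatter); with this step, compound 3 stands apart from both compounds that carry a ring on a single methylene at the nitrogen, where earlier only compound 2 could be set against it. Nothing in the available data accounts for either step.

As far as these compounds go, it remains open whether a phenyl ring or a pyridin-2-yl ring at the end of the methylene would stay within the scatter of compound 2. From the compounds shown here alone, a longer chain between the nitrogen and the ring is equally open.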